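Benzyl variation on the shared core: trifluoro to chloro-fluoro

The compounds below may be only part of what the source reports. "The series", "measured", "known", "first", "only" and "open" are said of these compounds alone.

Within the data shown here, compound 1 `COc1ccc(N2C(=O)N(Cc3c(F)cc(F)cc3F)c3ccccc3S2(=O)=O)cc1OC` is the one compound with a number in an assay on isolated protein for displacement of a labelled ligand from Orexin/Hypocretin receptor type 1 (Homo sapiens), with a stated time of 90 min; a higher number here means a weaker inhibitor, a lower number a stronger inhibitor: compound 1 gives 50.1 nM. Compound 2 `COc1ccc(N2C(=O)N(Cc3ccc(F)cc3Cl)c3ccccc3S2(=O)=O)cc1OC` reaches only a limit in this assay, > 2510 nM. Among the measured compounds shown here, that reading, (the limit of > 2510 nM in this assay, at which 1 of the 2 values shown sits), is the sole evidence on changing the benzyl group: an at least 50-fold higher number from compound 1 to compound 2 (1.69 log units; beyond the scatter). Compound 3 `COc1ccc(N2C(=O)N(Cc3c(F)cccc3Cl)c3ccccc3S2(=O)=O)cc1OC` differs from compound 1 by 2-chloro-6-fluorophenyl in place of 2,4,6-trifluorophenyl on a saturated chain carbon bound to an amide-type nitrogen in a ring. The measured step was a large loss, yet 2-chloro-6-fluorophenyl sits nearer to 2,4,6-trifluorophenyl than 2-chloro-4-fluorophenyl does, so a smaller loss is expected: a 3.2-fold higher number from compound 1 to compound 3 (0.50 log units; beyond the scatter). Compound 3 is estimated at 160 nM, within 30 nM to 1000 nM.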

Compound 3, inhibition constant: 7.94 nM
Beside the measured number, compound 3's estimate is 20-fold (1.30 log units) above it; measured number outside the range, below it.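

In this assay, 2-chloro-6-fluorophenyl outperforms 2,4,6-trifluorophenyl on the benzyl carbon, so a chlorine here need not cost binding: a 6.3-fold lower number from compound 1 to compound 3 (0.80 log units; beyond the scatter). Compound 2 and compound 3 carry the same two halogens, and the arrangement alone, 2-chloro-4-fluorophenyl against 2-chloro-6-fluorophenyl, separates them: an at least 310-fold lower number from compound 2 to compound 3 (2.49 log units; beyond the scatter). The size of that step rests on a limit of the assay, not a number: the limit of > 2510 nM in this assay, at which 1 of the 3 values shown sits.

On these data alone, whether a bromine, a methyl or a nitrile in place of the chlorine of 2-chloro-6-fluorophenyl would keep this binding remains open. Changes elsewhere on the shared core also remain open.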